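The source may hold more compounds than are shown below. What is called first, only, known or untested is meant among the compounds shown, and "the series" means these compounds.

Compound 1 `CC1(C)CC(NC(=O)Nc2ccccc2Cl)c2cc(F)ccc2O1`: 40000 nM
Compound 2 `CC1(C)CC(NC(=O)NCc2ccccc2)c2cc(Br)ccc2O1`: 27000 nM

In a functional assay on U-373MG ATCC cells (Homo sapiens) for inhibition, read by MTT assay, with a stated time of 72 h (on this read-out higher numbers stand for weaker inhibition and lower numbers for stronger inhibition), compound 2 gives 27000 nM, a value within the usual scatter of compound 1 at 40000 nM. Compound 3 `CC1(C)CC(NC(=O)Nc2ccccc2Cl)c2cc(Br)ccc2O1` has 2-chlorophenyl in place of the benzyl of compound 2 on an amide-type nitrogen: 2-chlorophenyl in place of benzyl on an amide-type nitrogen. Among the measured compounds shown here, no measured pair shows this change alone. Still, compound 1, which also bears 2-chlorophenyl, gives 40000 nM, so no step beyond the scatter is expected in this assay. The estimated step is a 1.1-fold higher number from compound 2 to compound 3 (0.05 log units; within the scatter). The expected value for compound 3 is 30000 nM, with an estimated range of 13000 nM to 65000 nM.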

Compound 3, half-maximal inhibitory concentration: 19000 nM
Compound 3: middle estimate off by 1.6-fold (0.20 log units), on the high side; the range from low to high includes it.
By their numbers in this assay, from the lowest: compounds 3, 2 and 1 (each within the scatter of the next, the first and the last beyond it).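

Putting 2-chlorophenyl in place of benzyl on the amide-type nitrogen gives a 1.4-fold lower number from compound 2 to compound 3 (0.15 log units; within the scatter) and so does not separate the two groups in this assay. Bromo in place of fluoro on the aromatic carbon gives a 2.1-fold lower number from compound 1 to compound 3 (0.32 log units; beyond the scatter) and is the first modest step here that clears the usual scatter. Nothing measured here explains that step.

From the compounds shown here alone, it remains open whether chloro on that aromatic carbon, or phenethyl on the amide-type nitrogen, would move the number further. A single swap of fluoro for bromo cannot establish a trend across halogens.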